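The source may hold more compounds than are shown below. What is called first, only, known or untested is meant among the compounds shown, and "the series" means these compounds.

Values so far in a functional assay on LoVo cells (Homo sapiens) for inhibition, read by colorimetric assay and MTT assay, with a stated time of 72 h (a higher number here means a weaker inhibitor, a lower number a stronger inhibitor), for three compounds:
- compound 1 `Cn1c2cnc1OCCCCCCCCOc1cc3ccccc3cc1-2` gives 16000 nM
- compound 2 `C=CCCCCOc1cc(F)ccc1-c1cnc(OCCC=C)n1C` gives 45000 nM
- compound 3 `CCCCCCOc1ncc(-c2ccccc2OC)n1C` gives 27000 nM

Compound 3 at 27000 nM lies between compound 1 and compound 2, within the scatter of each. The change to compound 4 `COc1ccccc1-c1cnc(OC)n1C` is hydrogen in place of pentyl on a saturated chain carbon bound to an oxygen on an aromatic ring with hydrogen in place of pentyl on a saturated chain carbon bound to an oxygen on an aromatic ring, so hexyloxy becomes methoxy. Among the compounds with values here, no measured pair shows this change alone, and the data give no direct size for it. All three measured compounds carry longer chains than the methoxy of compound 4. The expected step in this assay is a 2.2-fold higher number from compound 3 to compound 4 (0.35 log units; beyond the scatter) and points to a weaker inhibitor, held with modest confidence. The estimate for compound 4 is 60000 nM with an expected range from 25000 nM to 150000 nM in this read-out.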

Compound 4, half-maximal inhibitory concentration: 73000 nM
The estimate for compound 4 lay 1.2-fold (0.09 log units) below the measured number; the range from low to high includes it.
By their numbers in this assay, from the lowest: compounds 1, 3, 2 and 4 (each within the scatter of the next, the first and the last beyond it).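

In this assay the change from hexyloxy to methoxy gives the first single-place measure at this position, and the shorter group gives a weaker inhibitor (a 2.7-fold higher number from compound 3 to compound 4 (0.43 log units; beyond the scatter)). This is one pair, so it sets a direction for this change only and no trend across chain lengths. Nothing available gives a cause for this step.

On these data alone, whether a decyloxy chain would give a stronger inhibitor than hexyloxy remains open. So does the effect of a chain ending in an amine or a carboxylic acid.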